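The compounds below may be only part of what the source reports. "The series", "measured", "known", "first", "only" and "open" are said of these compounds alone.

Working notes on the series. In a physicochemical assay for solubility (on this read-out higher numbers stand for higher solubility and lower numbers for lower solubility), compound 3 (`CC(C)(C)CC(=O)N1CCC[C@H]1C(=O)N1CCC(NS(=O)(=O)c2cc(S(=O)(=O)c3ccccc3)ccc2C(F)(F)F)CC1`) is the lowest of the three measured compounds, at 25000 nM. Compound 1 (`CN(C)CC(=O)N1CCC(NS(=O)(=O)c2cc(S(=O)(=O)c3ccccc3)ccc2C(F)(F)F)CC1`) gives 100000 nM and compound 2 (`O=C(Cn1ccnc1)N1CCC(NS(=O)(=O)c2cc(S(=O)(=O)c3ccccc3)ccc2C(F)(F)F)CC1`) gives 100000 nM, which is no change at the digits printed from compound 1 to compound 2 (within the scatter).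

The next step leads to compound 4 (`CN(C)CC(=O)N1CCC[C@H]1C(=O)N1CCC(NS(=O)(=O)c2cc(S(=O)(=O)c3ccccc3)ccc2C(F)(F)F)CC1`), with dimethylamino in place of tert-butyl on a saturated chain carbon bound to a carbonyl carbon. The same difference reads neopentylcarbonyl to ((dimethylamino)methyl)carbonyl. For the measured compounds named here, no measured pair shows this exact change.

Going by the values given here, two measured steps bear on it most closely: a 4.0-fold lower number from compound 1 to compound 3 (0.60 log units; beyond the scatter), and a 4.0-fold lower number from compound 2 to compound 3 (0.60 log units; beyond the scatter). Both are modest, and both bring in the 1-(neopentylcarbonyl)pyrrolidin-2-yl group that compound 4 alters only at its tert-butyl end. Dimethylamino also occurs in compound 1, at 100000 nM, but there without the extra pyrrolidin-2-yl unit that compound 4 retains.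

In this assay a modest move to a higher number is therefore expected, of about the same size as those two steps or smaller. The estimated change is a 2.4-fold higher number from compound 3 to compound 4 (0.38 log units; beyond the scatter). For compound 4 the expected value is 60000 nM, with an estimated range of 25000 nM to 120000 nM.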

Compound 4, solubility: 100000 nM
Compound 4: middle estimate off by 1.7-fold (0.22 log units), on the low side, within the range that was stated.
By their numbers in this assay, from the lowest: compound 3; then compounds 1, 2 and 4 (each within the scatter of the next).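

Working notes, continued. In this assay the tert-butyl end of the side chain proves to matter, since dimethylamino in place of tert-butyl on a saturated chain carbon bound to a carbonyl carbon gives a 4.0-fold higher number from compound 3 to compound 4 (0.60 log units; beyond the scatter) and this is the only step shown in which the pyrrolidin-2-yl unit stays in place. With that unit retained, the series also shows no change at the digits printed from compound 1 to compound 4 (within the scatter) and no change at the digits printed from compound 2 to compound 4 (within the scatter) so that, among these four compounds, the lower number goes with tert-butyl in compound 3 and not with the pyrrolidin-2-yl unit alone. No measurement to hand accounts for this step.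

From the compounds shown here alone, it remains open whether the result is particular to dimethylamino or would also hold for 1H-imidazol-1-yl, morpholine or a carboxylic acid at this same place on the pyrrolidin-2-yl side chain. Also open, going by these compounds, is how a longer chain ending in tert-butyl, or a simple methyl in its place, would read in this assay with the rest of compound 3 unchanged.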